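The source may hold more compounds than are shown below. What is called first, only, known or untested is meant among the compounds shown, and "the series" means these compounds.

Within the data shown here, in a functional assay on NCI-H460 cells (Homo sapiens) for cytotoxicity, read by MTT assay, with a stated time of 72 h (a lower number here means a stronger inhibitor, a higher number a weaker inhibitor), compound 3 `COc1cc2c(Oc3ccc(NC(=O)c4cc(-c5ccc(C(F)(F)F)cc5)ccn4)cc3F)ccnc2cc1OCCCN1CCCCC1` gives 360 nM, the highest of the three numbers measured so far, although its gap to compound 1 is small. Compound 1 `COc1cc2c(Oc3ccc(NC(=O)c4cc(-c5ccc(F)cc5)ccn4)cc3F)ccnc2cc1OCCCN1CCCCC1` gives 250 nM in this assay, and compound 2 `COc1cc2c(Oc3ccc(NC(=O)c4cc(-c5ccccc5F)ccn4)cc3F)ccnc2cc1OCCCN1CCCCC1` gives 130 nM. Compound 4 `COc1ccc(-c2ccnc(C(=O)Nc3ccc(Oc4ccnc5cc(OCCCN6CCCCC6)c(OC)cc45)c(F)c3)c2)cc1` differs from compound 3 by methoxy in place of trifluoromethyl on an aromatic carbon. The measured steps that touch this position are a 1.4-fold higher number from compound 1 to compound 3 (0.16 log units; within the scatter), which stays within the scatter, and a 2.8-fold higher number from compound 2 to compound 3 (0.44 log units; beyond the scatter), which is modest. Exchanging one small group for another at this place has so far moved the number little, so the step is expected to be small and, if anything, downward, estimated as a 1.4-fold lower number from compound 3 to compound 4 (0.16 log units; within the scatter). Compound 4 is therefore expected to give 250 nM, with a range from 100 nM to 650 nM.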

Compound 4, half-maximal inhibitory concentration: 200 nM
Beside the measured number, compound 4's estimate is 1.3-fold (0.10 log units) above it; the measured number falls inside the stated range.
By their numbers in this assay, from the lowest: compounds 2, 4, 1 and 3 (each within the scatter of the next, the first and the last beyond it).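

In this assay, among these compounds, methoxy, the first group here to bring an oxygen to this position, gives (a 1.8-fold lower number from compound 3 to compound 4 (0.26 log units; within the scatter)) against trifluoromethyl and (a 1.3-fold lower number from compound 1 to compound 4 (0.10 log units; within the scatter)) against fluoro, both within the scatter. The change from 2-fluorophenyl to 4-methoxyphenyl gives (a 1.5-fold higher number from compound 2 to compound 4 (0.19 log units; within the scatter)), also within the scatter, so compound 4 stays close to compound 2, a closeness compound 3 does not share. Nothing available explains these small steps. As far as these compounds go, whether an amine or a carboxylic acid at this position would stay in the same range remains open, as does a longer chain such as butoxy.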